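The source may report more compounds than this note shows. Statements on the series, on what has been measured and on what is new or still open speak of the compounds shown alone.

Compound 1 `c1ccc(-c2noc(-c3ccncc3)n2)cc1` gives 497000 nM in a functional assay on MIA PaCa-2 cells (Homo sapiens) for antiproliferative activity, read by MTT assay, with a stated time of 24 h; a higher number here means a weaker inhibitor, a lower number a stronger inhibitor. Compound 2 `COc1ccc(-c2noc(-c3cccnc3)n2)cc1OC1CCCC1` gives only a limit of this assay, > 1000000 nM. Compound 3 `COc1ccc(-c2noc(Cc3c[nH]c4ccccc34)n2)cc1OC1CCCC1` gives 9560 nM.

Compound 2 therefore stands at the limit of > 1000000 nM in this assay, at which 1 of the 3 values shown sits, a limit rather than a measured number. Compound 4, `COc1ccc(-c2noc(-c3ccc(O)cc3)n2)cc1OC1CCCC1`, has not yet been measured. It differs from compound 2 in a single place: 4-hydroxyphenyl in place of pyridin-3-yl on an aromatic carbon. Among the measured compounds shown here, no pair of measured compounds shows this same change, so its effect cannot be read from a measured step. The step of an at least 3.3-fold lower number from compound 2 to compound 4 (0.52 log units; beyond the scatter) is expected to be modest and toward stronger inhibition, with little confidence in its size. Compound 4 is estimated at 300000 nM, in a range from 60000 nM to 1000000 nM.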

Compound 4, half-maximal inhibitory concentration: 480 nM
Compound 4: middle estimate off by 630-fold (2.80 log units), on the high side, outside the stated range (below it).
By their numbers in this assay, from the lowest: compound 4; then compound 3; then compound 1. At a limit, above all of these: compound 2.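

At this position on the shared core, 4-hydroxyphenyl in place of pyridin-3-yl gives an at least 2000-fold lower number from compound 2 to compound 4 (3.31 log units; beyond the scatter) in this assay. Among the compounds shown here, this is the first single change that can be read, and it shows that the group here can matter greatly. For compound 2, the starting point is a limit and not a measured number: the limit of > 1000000 nM in this assay, at which 1 of the 4 values shown sits.

The change removes a ring nitrogen and adds a hydroxy group at once, and the compounds shown do not separate the two. A plain phenyl, a methoxyphenyl or an aminophenyl at this position would help tell them apart.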